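Notes on the step from compound 3 to compound 4

The compounds below may be only part of what the source reports. "The series", "measured", "known", "first", "only" and "open" are said of these compounds alone.

Measured in an ADME assay on HeLa cells (Homo sapiens) for cytotoxicity, read by resazurin assay, with a stated time of 65 h; on this read-out higher numbers stand for an effect only at larger amounts of compound and lower numbers for an effect already at smaller amounts:
- compound 1 `CCNC(=O)c1cc(CC)sc1NC(=O)c1ccc([N+](=O)[O-])o1`: > 20000 nM (a limit)
- compound 2 `CCc1cc(C(N)=O)c(NC(=O)c2ccc([N+](=O)[O-])o2)s1`: > 20000 nM (a limit)
- compound 3 `CCc1cc(C(=O)NCCO)c(NC(=O)c2ccc([N+](=O)[O-])o2)s1`: > 20000 nM (a limit)

No number has been obtained for any of these compounds so far. Compound 3 stands at a limit (> 20000 nM), not at a measured value. The series as a whole shows (the limit of > 20000 nM in this assay, at which 3 of the 3 values shown sit).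

The next compound is compound 4 `CCc1cc(C(=O)O)c(NC(=O)c2ccc([N+](=O)[O-])o2)s1`. The change is hydroxy in place of (2-hydroxyethyl)amino on a carbonyl carbon. In words, this is hydroxy in place of (2-hydroxyethyl)amino on a carbonyl carbon, or (2-hydroxyethyl)carbamoyl to carboxy when cut one bond further out.

Among the compounds with values here, three measured steps bear on this change, all of them altering the substituent on the amide-type nitrogen: a step that the two limits leave unreadable from compound 1 to compound 2, a step that the two limits leave unreadable from compound 1 to compound 3 and a step that the two limits leave unreadable from compound 2 to compound 3. None has a readable size, and none replaces that nitrogen with hydroxy, so they give no direction for the new change.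

In this assay, the expectation is therefore no step beyond the scatter. The step expected is a step that the limit leaves unreadable from compound 3 to compound 4, resting on compound 3 at > 20000 nM. For compound 4 the estimated value is 25000 nM, with an expected range of 12000 nM to 50000 nM, and another limit is the likeliest report.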

Compound 4, half-maximal effective concentration: > 20000 nM
Compound 4 was reported as a limit; the forecaster's own chance of this, stated with the estimate: 85%; the middle value lies beyond the limit too.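

In this assay, within the data shown here, compound 4 gives > 20000 nM, which is a limit, so no step from compound 1, compound 2 or compound 3 to compound 4 can be read. The compounds shown leave open the size and direction of every change on the carbonyl carbon: the limit of > 20000 nM in this assay, at which 4 of the 4 values shown sit.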